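The compounds below may be only part of what the source reports. "The series", "measured", "known", "first", "only" and "open" are said of these compounds alone.

In an ADME assay on the whole organism (plasma, Rattus norvegicus) for metabolic stability, read by LC-MS, at a dose of 0.1 mg/kg by the intravenous route (on this read-out higher numbers stand for fast clearance and lower numbers for slow clearance), compound 1 `Cc1cnc(Oc2cc(Cl)c(F)c(-c3ccc4c(c3)CC[C@H](CCC(=O)O)O4)c2)s1` gives 6200 mL/min/kg. Two relatives have also been measured: compound 2 `O=C(O)CC[C@H]1CCc2cc(-c3cc(OC4CCC4)cc(F)c3F)ccc2O1` gives 8700 mL/min/kg, and compound 3 `O=C(O)CC[C@H]1CCc2cc(-c3nc(OC4CCC4)ccc3F)ccc2O1` gives 4500 mL/min/kg. Compound 1 therefore stands within the usual scatter of both. Compound 4 `COc1cc(Oc2ncc(C)s2)cc(-c2ccc3c(c2)CC[C@H](CCC(=O)O)O3)c1F` differs from compound 1 in one place: methoxy in place of chloro on an aromatic carbon, with methoxy in place of chloro on an aromatic carbon, ortho to a fluoro group. Going by the values given here, no measured pair shows this exchange, so the data offer no direct precedent, and no change beyond the scatter is expected in this assay. The expected size of the change is small, as the estimated 1.0-fold lower number from compound 1 to compound 4 (0.01 log units; within the scatter) shows. For compound 4, the estimate is 6000 mL/min/kg, with an expected range of 3000 mL/min/kg to 12000 mL/min/kg.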

Compound 4, clearance: 3600 mL/min/kg
The estimate for compound 4 lay 1.7-fold (0.22 log units) above the measured number; low and high end bracket the measured number.
By their numbers in this assay, from the lowest: compounds 4, 3, 1 and 2 (each within the scatter of the next, the first and the last beyond it).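

In this assay, going by these compounds alone, methoxy in place of chloro on this aromatic carbon, ortho to a fluoro group, gives a 1.7-fold lower number from compound 1 to compound 4 (0.24 log units; within the scatter) and is the first exchange at this position that can be read directly. In this one pair, the larger methoxy group with its hydrogen-bond acceptor leaves clearance within the usual scatter of repeated measurements. Nothing at hand explains the result in terms of cause. As far as these compounds go, whether an amine or a nitrile at this position would shift clearance beyond the scatter remains open. So does whether the same exchange would give a similar result on a different group in place of the (5-methyl-1,3-thiazol-2-yl)oxy group.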